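The source may hold more compounds than are shown below. What is called first, only, known or untested is meant among the compounds shown, and "the series" means these compounds.

Measured so far:
compound 3 `N#Cc1ccc(C(=O)/C=C/c2ccncc2)cc1`: 123000 nM
compound 1 `C(=C/c1noc2ccccc12)\c1ccncc1`: > 100000 nM
compound 2 `CO/N=C(\C=C\c1ccncc1)c1cc(OC)c(OC)c(OC)c1`: > 100000 nM

In a functional assay with Rattus norvegicus as the target (a higher number here means a weaker inhibitor, a lower number a stronger inhibitor), compound 3 gives 123000 nM. Going by the values given here, that is the only number among the three values shown, the two others sitting at a limit of the assay (the limit of > 100000 nM in this assay, at which 2 of the 3 values shown sit). For compound 1 the value > 100000 nM is such a limit. For compound 2 the value > 100000 nM is likewise a limit. Compound 4 `O=C(/C=C/c1ccncc1)c1ccccc1` differs from compound 3 in one place: hydrogen in place of cyano on an aromatic carbon. Among the compounds with values here, no step between measured compounds is available for comparison, so the effect of this change rests on the weak position of compound 3 alone. In this assay no step beyond the usual scatter is expected, in either direction. Compound 4 is therefore estimated at 150000 nM, within 50000 nM to 450000 nM, an expected step of a 1.2-fold higher number from compound 3 to compound 4 (0.09 log units; within the scatter).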

Compound 4, half-maximal inhibitory concentration: 49000 nM
Compound 4: middle estimate off by 3.1-fold (0.49 log units), on the high side; the measured number lies below the stated range.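

In this assay, hydrogen in place of cyano on an aromatic carbon, para to a large group, gives a 2.5-fold lower number from compound 3 to compound 4 (0.40 log units; beyond the scatter). This position therefore responds to substitution, and cyano is not required there for the activity seen, since the compound without it has the lower number. No measured property accounts for the step.

As far as these compounds go, whether an amine or a carboxylic acid at this position would lower the number further remains open. Going by these compounds alone, only this one step can be read, and the remaining values give no numbers to compare: the limit of > 100000 nM in this assay, at which 2 of the 4 values shown sit.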